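Methyl Added to the Aniline Ring of a Sulfone

The source may report more compounds than this note shows. Statements on the series, on what has been measured and on what is new or still open speak of the compounds shown alone.

Of the compounds shown here, three sharing one core have been measured. Compound 1 `Cc1ccc(/C=C2\CCCC(CN(C)c3ccccc3)C2=O)cc1` gives 44.7% in a functional assay on the whole organism (strain Wistar) for inhibition, with Rattus norvegicus as the target, read by paw edema, with stated times of 1 h and 3 h, at a dose of 200 mg/kg by the oral route; a lower number here means less inhibition, a higher number more inhibition at the dose given (going by the name of the read-out). Compound 2 `Cc1ccc(/C=C2\CCCC(CN(C)c3ccc(C)cc3)C2=O)cc1` differs from compound 1 in that (methyl in place of hydrogen on an aromatic carbon); compound 2 gives 38.3%, and the step is a number 6.4 percentage points lower from compound 1 to compound 2 (within the scatter). Compound 3 `CN(CC1CCC/C(=C\c2ccc(S(C)(=O)=O)cc2)C1=O)c1ccccc1` carries a different core, the difference being (methylsulfonyl in place of methyl on an aromatic carbon), and compound 3 gives 51.1%; the step is a number 6.4 percentage points higher from compound 1 to compound 3 (within the scatter). Compound 3 has the highest of the three numbers, within the scatter of compound 1 and beyond the scatter of compound 2.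

Compound 4 `Cc1ccc(N(C)CC2CCC/C(=C\c3ccc(S(C)(=O)=O)cc3)C2=O)cc1` has not yet been measured. It differs from compound 3 in that (methyl in place of hydrogen on an aromatic carbon), the same change already seen from compound 1 to compound 2, at a place described in identical words, but now on the core of compound 3.

Because a number 6.4 percentage points lower from compound 1 to compound 2 (within the scatter) stayed within the scatter, the step from compound 3 to compound 4 is expected to be of similar size, estimated as a number 6.1 percentage points lower from compound 3 to compound 4 (within the scatter). Compound 4 is therefore expected to give about 45% in this assay, estimated to fall between 32% and 58%.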

Compound 4, a percentage reported as inhibition, in the whole organism at one dose (the size of the read-out at that dose, not a potency): 31.9%
Compound 4: middle estimate off by 13.1 percentage points, on the high side, outside the stated range (below it).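

In this assay, the change from phenyl to 4-methylphenyl on the core of compound 3 amounts to a number 19.2 percentage points lower from compound 3 to compound 4 (beyond the scatter), and set beside the same change on the core of compound 1, the gap between the two steps does not exceed what two such steps can scatter: the same change on two cores in this assay, a number 6.4 percentage points lower (within the scatter) from compound 1 to compound 2 and a number 19.2 percentage points lower (beyond the scatter) from compound 3 to compound 4, 12.8 percentage points apart, within the scatter of two such steps

The other change, methylsulfonyl in place of methyl on an aromatic carbon, reads the same way, with a number 6.4 percentage points lower from compound 2 to compound 4 (within the scatter): the same change on two cores in this assay, a number 6.4 percentage points higher (within the scatter) from compound 1 to compound 3 and a number 6.4 percentage points lower (within the scatter) from compound 2 to compound 4, 12.8 percentage points apart, within the scatter of two such steps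

Among the compounds shown here, these four compounds therefore give no ground to say that either change behaves differently from one core to the other, but with only one pair per core they do not show that it carries over unchanged either.

The compounds shown leave open how a chlorine, a methoxy group or a carboxylic acid would behave at the place taken by the methyl on the 4-methylphenyl ring. They also leave open what a longer chain in place of the methyl on the amine nitrogen would do on either core.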